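This account rests on a few compounds, and the source may have more. Where it says the series, first, only, none or still open, it means among the compounds named here.

In an ADME assay on microsomes from liver (Mus musculus) for metabolic stability, read by LC-MS, with NADPH named in the record, with a stated time of 60 min, tested at 1 uM, in the absence of a further agent (on this read-out higher numbers stand for a more stable compound and lower numbers for a less stable compound), compound 3 `COc1ccc(-c2c(C)nc3c(N4CC[C@@H](NC(=O)C(F)(F)F)C4)cc(C)nn23)cc1OC` gives > 95%, which is a limit of the assay and not a number. Compound 1 `COc1cc(-c2c(C)nc3c(N4CC[C@@H](NC(C)=O)C4)cc(C)nn23)ccc1F` reads > 95%, also a limit. Compound 2 `CC(=O)N[C@@H]1CCN(c2cc(C)nn3c(-c4cccs4)c(C)nc23)C1` reads > 95%, again a limit. The whole measured set therefore rests on (the limit of > 95% in this assay, at which 3 of the 3 values shown sit), and compound 3 cannot be ranked against its two companions.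

Compound 4 `COc1ccc(-c2c(C)nc3c(N4CC[C@@H](NS(C)(=O)=O)C4)cc(C)nn23)cc1OC` departs from compound 3 in one place: methylsulfonyl in place of (trifluoromethyl)carbonyl on an amine nitrogen. Among the compounds with values here, the only measured step is a step that the two limits leave unreadable from compound 1 to compound 2. Within the data shown here, it falls on an aromatic carbon rather than on an amine nitrogen, and its size cannot be read, so no measured step speaks directly to this exchange.

With only the limit of compound 3 at > 95% to start from, no firm direction can be drawn. The expected change in this assay is a number no higher from compound 3 to compound 4 (the limit leaves the size open), an estimated step that stays within the usual scatter. For compound 4 the estimated value is 95%, with an expected range from 82% to 100%.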

Compound 4, percent of the compound remaining: > 95%
Compound 4 ended at the assay's limit; the forecaster's own chance of this, stated with the estimate: 60%; the middle value sits exactly at the limit.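

In this assay compound 4 gives > 95%, a limit of the assay and not a number. Compound 3 also stands at a limit, so no step can be read between compound 3 and compound 4. The compounds shown leave open how their stability ranks, and the whole set still rests on one limit: the limit of > 95% in this assay, at which 4 of the 4 values shown sit.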